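The compounds below may be only part of what the source reports. "The series", "measured", "known", "first", "only" and "open" are said of these compounds alone.

In an assay on CHO cells for displacement of a labelled ligand from prostaglandin D2 receptor 2 (Homo sapiens), read by scintillation counting (on this read-out higher numbers stand for weaker inhibition and lower numbers for stronger inhibition), compound 1 `Cc1ccc(S(=O)(=O)Cc2ccccc2)cc1C#Cc1cc(Cl)ccc1OCC(=O)O` gives 5 nM, the lowest of the three numbers recorded so far. Compound 2 `CS(=O)(=O)c1cccc(C#Cc2cc(Cl)ccc2OCC(=O)O)c1` gives 15 nM in this assay, and compound 3 `CCCS(=O)(=O)c1cccc(C#Cc2cc(C#N)ccc2OCC(=O)O)c1` gives 21 nM; both of these steps from compound 1 lie beyond the usual scatter, so compound 1 stands as the most potent of the three measured compounds. Compound 4 `Cc1ccc(S(=O)(=O)N(C)CCCN(C)C)cc1C#Cc1cc(Cl)ccc1OCC(=O)O` has not yet been measured in this assay. It differs from compound 1 in a single place: (3-(dimethylamino)propyl)(methyl)amino in place of benzyl on a sulfonyl sulfur. The group that leaves carries one six-membered aromatic ring of carbon only, while the group that enters has no ring and adds one hydrogen-bond acceptor. For the measured compounds named here, no measured pair in this set shows the same change, so there is no direct precedent for its size. For compound 4 the expected step is a 6.0-fold higher number from compound 1 to compound 4 (0.78 log units; beyond the scatter), a move toward weaker inhibition that is expected to exceed the scatter. The estimate for compound 4 is 30 nM, with an expected range from 8 nM to 120 nM.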

Compound 4, inhibition constant: 287 nM
Beside the measured number, compound 4's estimate is 9.6-fold (0.98 log units) below it; measured number above the stated range.
By their numbers in this assay, from the lowest: compound 1; then compounds 2 and 3 (each within the scatter of the next); then compound 4.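

In this assay, for the compounds shown here, the sulfonyl sulfur of compound 1 proves sensitive to what it carries: (3-(dimethylamino)propyl)(methyl)amino in place of benzyl gives a 57-fold higher number from compound 1 to compound 4 (1.76 log units; beyond the scatter), the only single-place step in this set and a large one. The two groups have similar heavy-atom counts, so a comparable count on this sulfur does not keep the number low once the six-membered aromatic ring of carbon only gives way to a ringless group with one hydrogen-bond acceptor. No measurement of any property of these compounds bears on this result.

This one step changes the ring, the chain and the nitrogen content together, and the compounds shown cannot tell which of these matters. A benzylamino group or a plain butyl chain on the same sulfur would help separate them.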